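From methoxy to chloro on a shared core

The compounds below may be only part of what the source reports. "The series", "measured", "known", "first", "only" and "open" are said of these compounds alone.

Compound 3 (`COc1ccc2c(=O)c(Cc3ccccc3)c(C)[nH]c2c1`) gives 5000 nM in a physicochemical assay for solubility, read by HPLC, at pH 7.4 (on this read-out lower numbers stand for lower solubility and higher numbers for higher solubility), and sits within the scatter of compound 1 (`Cc1[nH]c2ccccc2c(=O)c1Cc1ccccc1`), which gives 10000 nM in the same test. Compound 2 (`COc1ccc2[nH]c(C)c(Br)c(=O)c2c1`) shows > 20000 nM as its reading, a limit of the assay and not a number. Compound 4 (`Cc1[nH]c2cc(Cl)ccc2c(=O)c1Cc1ccccc1`) differs from compound 3 by chloro in place of methoxy on an aromatic carbon. For the measured compounds named here, only one measured step bears on this change, methoxy in place of hydrogen on an aromatic carbon, and a 2.0-fold lower number from compound 1 to compound 3 (0.30 log units; within the scatter) stays within the scatter. No shift beyond the scatter is therefore expected in this assay and the estimated change is small (a 1.3-fold lower number from compound 3 to compound 4 (0.10 log units; within the scatter)). Compound 4 is estimated at 4000 nM as its expected value (range from 1500 nM to 10000 nM).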

Compound 4, solubility: < 2000 nM
Compound 4 ended at the assay's limit; the forecaster's own chance of this, stated with the estimate: 10%; at least 2.0-fold (0.30 log units) between middle value and limit.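

For the compounds shown here, at this aromatic carbon, the earlier swap of hydrogen for methoxy had stayed within the scatter, whereas chloro is the first group here to move the reading beyond it. Chloro in place of methoxy gives an at least 2.5-fold lower number from compound 3 to compound 4 (0.39 log units; beyond the scatter), and chloro in place of hydrogen gives an at least 5.0-fold lower number from compound 1 to compound 4 (0.69 log units; beyond the scatter). Compound 4 reads < 2000 nM, which is a limit of the assay and not a number, so each step gives only a minimum size.

Going by these compounds, how far the true reading of compound 4 lies from that limit remains open. So does the effect of an amine or a carboxylic acid at this carbon on this assay.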